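Sulfonyl Benzamide Anilides: Side-Chain Branching Versus Aryl Substituent

The compounds below may be only part of what the source reports. "The series", "measured", "known", "first", "only" and "open" are said of these compounds alone.

Measured so far in a functional assay for inhibition, read by spectrophotometry, with a stated time of 20 min, tested at 3 mg/mL; on this read-out lower numbers stand for a weaker effect and higher numbers for a stronger effect at the one concentration tested:
compound 1, `CC(=O)c1ccc(NC(=O)C(CC(C)C)N(C(=O)c2ccccc2)S(=O)(=O)c2ccc(C)cc2)cc1`, 63.1%
compound 2, `CCC(C)C(C(=O)Nc1ccc(C(C)=O)cc1)N(C(=O)c1ccccc1)S(=O)(=O)c1ccc(C)cc1`, 33.4%
compound 3, `CC(=O)c1ccc(NC(=O)C(CC(C)C)N(C(=O)c2ccccc2)S(=O)(=O)c2ccc([N+](=O)[O-])cc2)cc1`, 62.3%

Compound 1 and compound 3 differ only in the aryl group of the sulfonyl part: nitro in place of methyl on an aromatic carbon. The corresponding step in this assay, a number 0.8 percentage points lower from compound 1 to compound 3 (within the scatter), is within the scatter, so the two numbers cannot be told apart. Compound 1 and compound 2 differ in the side chain on the central carbon: sec-butyl in place of isobutyl on a saturated chain carbon bound to an amide-type nitrogen and a carbonyl carbon. Here the step of a number 29.7 percentage points lower from compound 1 to compound 2 (beyond the scatter) is beyond the scatter and modest in size.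

Compound 4, `CCC(C)C(C(=O)Nc1ccc(C(C)=O)cc1)N(C(=O)c1ccccc1)S(=O)(=O)c1ccc([N+](=O)[O-])cc1`, is not yet measured. It stands to compound 3 as compound 2 stands to compound 1: sec-butyl in place of isobutyl on a saturated chain carbon bound to an amide-type nitrogen and a carbonyl carbon. The place is described in the same words for both pairs, so this is the same change on the core of compound 3. Because a number 0.8 percentage points lower from compound 1 to compound 3 (within the scatter) shows the two cores behave alike in this assay, the step is expected to resemble the earlier one, estimated as a number 29.3 percentage points lower from compound 3 to compound 4 (beyond the scatter). Compound 4 is therefore expected to give about 33% in this assay, estimated between 20% and 47%; this rests on one pair only.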

Compound 4, a percentage reported as inhibition, at one concentration (the size of the read-out at that concentration, not a potency): 42.1%
Compound 4: the middle estimate sits 9.1 percentage points below what was measured; the measured number falls inside the stated range.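

Sec-butyl in place of isobutyl again gives a number 20.2 percentage points lower from compound 3 to compound 4 (beyond the scatter) in this assay and matches the earlier step: the same change on two cores in this assay, a number 29.7 percentage points lower (beyond the scatter) from compound 1 to compound 2 and a number 20.2 percentage points lower (beyond the scatter) from compound 3 to compound 4, 9.5 percentage points apart, within the scatter of two such steps.
Nitro in place of methyl gives a number 8.7 percentage points higher from compound 2 to compound 4 (within the scatter) and also agrees with its earlier step: the same change on two cores in this assay, a number 0.8 percentage points lower (within the scatter) from compound 1 to compound 3 and a number 8.7 percentage points higher (within the scatter) from compound 2 to compound 4, 9.5 percentage points apart, within the scatter of two such steps.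
This shows the two changes carrying over between these cores only, at one concentration; it does not give a potency and does not show that either change carries over to any other core.

Open, going by these compounds, are side chains other than these two butyl groups, such as a longer chain or a cyclohexyl group. Also open, on these data alone, are other groups in place of the methyl and nitro, such as an amine or a carboxylic acid.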